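This account rests on a few compounds, and the source may have more. Where it says the series, first, only, none or still open, it means among the compounds named here.

Working notes on the series, values in a functional assay on A549 cells (Homo sapiens) for inhibition, read by colorimetric assay and MTT assay, with a stated time of 72 h; a lower number here means a stronger inhibitor, a higher number a weaker inhibitor:
- compound 1 `C=CCCCCCOc1ncc(-c2ccccc2OCCCCC=C)n1C`: 62000 nM
- compound 2 `C=CCCCCOc1ccccc1-c1cnc(OCCOCC=C)n1C`: 34000 nM
- compound 3 `Cn1c(-c2ccccc2O)cnc1S(=O)(=O)c1ccccc1`: > 100000 nM (a limit, not a number)
- compound 4 `C=CCCCCOc1ccccc1-c1cnc(S(=O)(=O)c2ccccc2)n1C`: not yet measured

Compound 3 stands at the limit of > 100000 nM in this assay, at which 1 of the 3 values shown sits. The change to compound 4 is hex-5-en-1-yl in place of hydrogen on an oxygen on an aromatic ring; the same difference reads hydroxy to (hex-5-en-1-yl)oxy.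

Within the data shown here, no measured step makes this change. Among the measured compounds shown here, the one measured step, a 1.8-fold lower number from compound 1 to compound 2 (0.26 log units; within the scatter), lies in the other ether chain and gives no size for the change at hand. It does show that compound 1 and compound 2 read alike. Both carry hex-5-en-1-yl on the oxygen on an aromatic ring, and both differ from compound 4 elsewhere on the shared core. For the measured compounds named here, compound 1 gives 62000 nM and compound 2 gives 34000 nM, and these two values are the only guide to where compound 4 may fall.

In this assay a step to a lower number is therefore expected, of a size that stays uncertain without a number for compound 3. The expected step is an at least 2.0-fold lower number from compound 3 to compound 4 (0.30 log units; that floor lies within the scatter). For compound 4 the estimate is 50000 nM, with an expected range of 20000 nM to 100000 nM.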

Compound 4, half-maximal inhibitory concentration: 38000 nM
Compound 4: the middle estimate sits 1.3-fold (0.12 log units) above what was measured; the measured number falls inside the stated range.
By their numbers in this assay, from the lowest: compounds 2, 4 and 1 (each within the scatter of the next). At a limit, above all of these: compound 3.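

Notes on the position: in this assay, compound 3, which carries the free hydroxy, gives only a limit and not a number: the limit of > 100000 nM in this assay, at which 1 of the 4 values shown sits.

Even so, the oxygen on the aromatic ring now has a first reading for this change, since hex-5-en-1-yl in place of hydrogen gives an at least 2.6-fold lower number from compound 3 to compound 4 (0.42 log units; beyond the scatter), a floor on the size of the step rather than its size. With hex-5-en-1-yl in place, the other substituent on the shared core varies with no readable effect: phenylsulfonyl in place of 2-(allyloxy)ethoxy gives a 1.1-fold higher number from compound 2 to compound 4 (0.05 log units; within the scatter), and phenylsulfonyl in place of (hept-6-en-1-yl)oxy gives a 1.6-fold lower number from compound 1 to compound 4 (0.21 log units; within the scatter), so compounds 1, 2 and 4 read alike.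

The compounds shown leave open the true size of the step from hydroxy to (hex-5-en-1-yl)oxy, and whether a methyl, a saturated hexyl or a longer chain on that oxygen would read like hex-5-en-1-yl. They also leave open how a chain ending in an amine or a carboxylic acid would read at that oxygen.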